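The source may hold more compounds than are shown below. What is called first, only, known or untested is meant among the compounds shown, and "the series" means these compounds.

Among the measured compounds shown here, in a functional assay on HeLa cells (Homo sapiens) for cytotoxicity, read by neutral red uptake, with a stated time of 3 days (on this read-out lower numbers stand for stronger inhibition and higher numbers for weaker inhibition), compound 3 `CCCCCCc1c(F)c(N)c2c(=O)cc(-c3ccc(N)c(F)c3)oc2c1F` gives 21000 nM, the only value in this set that is a number rather than a limit. Compound 1 `Nc1ccc(-c2cc(=O)c3c(N)c(F)cc(F)c3o2)cc1F` gives > 100000 nM, which is a limit of the assay. Compound 2 `Cc1c(F)c(N)c2c(=O)cc(-c3ccc(N)c(F)c3)oc2c1F` likewise gives > 100000 nM, also a limit. Compound 4 `C[S+]([O-])c1c(F)c(N)c2c(=O)cc(-c3ccc(N)c(F)c3)oc2c1F` differs from compound 3 by a group of 3 heavy atoms (1 carbon, 1 oxygen, 1 sulfur; no ring) in place of a group of 6 heavy atoms (6 carbon; no ring), on an aromatic carbon. For the measured compounds named here, two measured steps bear on this change: an at least 4.7-fold lower number from compound 1 to compound 3 (0.67 log units; beyond the scatter) and an at least 4.7-fold lower number from compound 2 to compound 3 (0.67 log units; beyond the scatter), both showing that the hexyl group goes with a lower number than hydrogen or methyl, as far as the limit of > 100000 nM in this assay, at which 2 of the 3 values shown sit, allows reading. Taking the hexyl away again and putting in the entering group is therefore expected to raise the number, as a 3.8-fold higher number from compound 3 to compound 4 (0.58 log units; beyond the scatter). Compound 4 is estimated at 80000 nM, with a range from 25000 nM to 300000 nM.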

Compound 4, half-maximal inhibitory concentration: > 100000 nM
Compound 4 was reported as a limit; the forecaster's own chance of this, stated with the estimate: 60%; middle value at least 1.2-fold (0.09 log units) away from the limit.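

In this assay the change from hexyl to the smaller sulfur-and-oxygen group on this aromatic carbon gives an at least 4.7-fold higher number from compound 3 to compound 4 (0.67 log units; beyond the scatter) and so undoes the gain seen with hexyl. Compound 4 gives > 100000 nM as a limit and not a number. Hexyl thus remains the only group at this place with a readable value, and the steps from compound 1 and from compound 2 to compound 4 cannot be read, because both ends of each are limits: the limit of > 100000 nM in this assay, at which 3 of the 4 values shown sit.

Still open, from the compounds shown here alone, is how much of the chain is needed, as a butyl or an octyl chain here would show, and whether an amine at this place would behave like hexyl.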